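Swapping the Aromatic Ring on the Amide Carbonyl

The source may hold more compounds than are shown below. What is called first, only, known or untested is meant among the compounds shown, and "the series" means these compounds.

Measured so far in an assay for binding affinity to 5-hydroxytryptamine receptor 1D (Homo sapiens), read by radioligand binding; a lower number here means a stronger inhibitor, a higher number a weaker inhibitor:
compound 1, `CN1CCC(c2c[nH]c3ccc(NC(=O)c4cccc(F)c4)nc23)CC1`: 690 nM
compound 2, `CN1CCC(c2c[nH]c3ccc(NC(=O)c4cccs4)nc23)CC1`: 650 nM

Compound 2 stands at the same level as compound 1; the step of a 1.1-fold lower number from compound 1 to compound 2 (0.03 log units; within the scatter) lies within the scatter, so the two cannot be told apart. Compound 3, `CN1CCC(c2c[nH]c3ccc(NC(=O)c4ccncc4)nc23)CC1`, differs from compound 2 in one place: pyridin-4-yl in place of thiophen-2-yl on a carbonyl carbon. For the measured compounds named here, the only measured step that bears on this exchanged one aromatic ring for another on a carbonyl carbon and changed little, so little change beyond the scatter is expected here, and for compound 3 the step of a 1.2-fold higher number from compound 2 to compound 3 (0.06 log units; within the scatter) is expected. Compound 3 is estimated at 750 nM, within 300 nM to 2000 nM.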

Compound 3, inhibition constant: 420 nM
The estimate for compound 3 lay 1.8-fold (0.25 log units) above the measured number; the range from low to high includes it.
By their numbers in this assay, from the lowest: compounds 3, 2 and 1 (each within the scatter of the next).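

Pyridin-4-yl on the carbonyl carbon sits level with the two earlier aromatic rings in this assay, with steps of a 1.5-fold lower number from compound 2 to compound 3 (0.19 log units; within the scatter) and a 1.6-fold lower number from compound 1 to compound 3 (0.22 log units; within the scatter). The three aromatic rings therefore cannot be told apart at this position, whether the ring holds sulfur, nitrogen or neither as a ring atom. No measurement at hand offers an explanation for this. On these data alone, it remains open whether a group other than an aromatic ring, such as a cyclohexyl ring, a short alkyl chain or an amine, would stay at this level on the same carbonyl carbon.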